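The compounds below may be only part of what the source reports. "The series", "measured", "known", "first", "only" and "open" are said of these compounds alone.

Compound 1 `CC1=C(C(=O)OC(C)C)C(c2ccccc2C(F)(F)F)N(C(=O)OC2CCN(Cc3ccccc3)CC2)C(=O)N1`: 50 nM
Compound 2 `CC1=C(C(=O)OC(C)C)C(c2ccccc2[N+](=O)[O-])N(C(=O)OC2CCN(Cc3ccccc3)CC2)C(=O)N1`: 8 nM
Compound 3 `CC1=C(C(=O)OCC(C)C)C(c2ccccc2C(F)(F)F)N(C(=O)OC2CCN(Cc3ccccc3)CC2)C(=O)N1`: 98 nM

In a functional assay (aorta) for inhibition, with Oryctolagus cuniculus as the target (a higher number here means a weaker inhibitor, a lower number a stronger inhibitor), compound 1 gives 50 nM. It sits level with compound 3, given a 2.0-fold higher number from compound 1 to compound 3 (0.29 log units; within the scatter), and clearly above compound 2, given a 6.3-fold lower number from compound 1 to compound 2 (0.80 log units; beyond the scatter). Compound 4 `CC1=C(C(=O)OC(C)C)C(c2ccccc2C(F)(F)F)N(C(=O)OC2CCN(Cc3ccc(Cl)cc3)CC2)C(=O)N1` differs from compound 1 by chloro in place of hydrogen on an aromatic carbon, which turns benzyl into 4-chlorobenzyl. Neither measured step bears directly on this change: a 6.3-fold lower number from compound 1 to compound 2 (0.80 log units; beyond the scatter) concerns the trifluoromethyl group, and a 2.0-fold higher number from compound 1 to compound 3 (0.29 log units; within the scatter) concerns the ester. For the measured compounds named here, no measured compound carries any change on the benzyl group, so no step beyond the scatter is expected, in either direction. The expected step is a 1.1-fold higher number from compound 1 to compound 4 (0.04 log units; within the scatter), with a wide margin. For compound 4 the estimated value is 55 nM, with a range from 18 nM to 170 nM.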

Compound 4, half-maximal inhibitory concentration: 55 nM
Beside the measured number, compound 4's estimate shows no gap at the digits printed, and the stated range covers the measured number.
By their numbers in this assay, from the lowest: compound 2; then compounds 1, 4 and 3 (each within the scatter of the next).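

For the compounds shown here, compound 4 is the only compound here changed on the benzyl group, and chloro in place of hydrogen gives a 1.1-fold higher number from compound 1 to compound 4 (0.04 log units; within the scatter) as its step. This place, on a six-membered aromatic ring and para to a large group, therefore takes one added chlorine atom with no change beyond the scatter. Nothing available here explains this result. Still open, on these data alone, is whether an amine, a carboxylic acid or a methoxy group at this same place would also stay within the scatter, and whether 4-chlorobenzyl would give a similar result alongside nitro in place of trifluoromethyl.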